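Replacing (piperidin-1-yl)methyl on a shared core

The compounds below may be only part of what the source reports. "The series", "measured", "known", "first", "only" and "open" are said of these compounds alone.

Measured in a functional assay on A-375 cells (Homo sapiens) for cytotoxicity, read by MTT assay, with a stated time of 72 h; a lower number here means a stronger inhibitor, a higher number a weaker inhibitor:
- compound 1 `CC1(C)O[C@@H](CO)[C@H](Cn2cc(Cn3c4c(c5ccccc53)C(=O)c3c[n+]([O-])c5ccccc5c3C4=O)nn2)O1`: 190 nM
- compound 2 `O=C1c2c[n+]([O-])c3ccccc3c2C(=O)c2c1c1ccccc1n2CCCCN1CCCCC1`: 190 nM
- compound 3 `O=C1c2c[n+]([O-])c3ccccc3c2C(=O)c2c1c1ccccc1n2CCN1CCCCC1`: 180 nM

At 180 nM, compound 3 stands within the scatter of both other compounds, so the three values cannot be ranked. The next compound, compound 4 `O=C1c2c[n+]([O-])c3ccccc3c2C(=O)c2c1c1ccccc1n2Cc1cn(C[C@@H](O)CO)nn1`, has not yet been measured. Its difference from compound 3 is 1-(2,3-dihydroxypropyl)-1H-1,2,3-triazol-4-yl in place of (piperidin-1-yl)methyl on a saturated chain carbon bound to an aromatic nitrogen. This places a new group on a saturated chain carbon bound to an aromatic nitrogen.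

Going by the values given here, only two measurements bear on this change, and neither tests it directly. Among the compounds with values here, the one measured step, a 1.1-fold lower number from compound 2 to compound 3 (0.02 log units; within the scatter), altered only the length of the chain carrying the piperidine ring, and it stayed within the scatter. Compound 1, with a different side chain on the shared core, gives 190 nM, which suggests that this assay's values can hold steady across unlike side chains. Within the data shown here, no measured compound carries the 2,3-dihydroxypropyl group, so the data give no direction for the change. A step beyond the scatter is therefore not expected, although the uncertainty is wide. The estimated step is a 1.1-fold higher number from compound 3 to compound 4 (0.05 log units; within the scatter). For compound 4 the estimated value is 200 nM, with an expected range of 90 nM to 450 nM.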

Compound 4, half-maximal inhibitory concentration: 140 nM
Compound 4: the middle estimate sits 1.4-fold (0.15 log units) above what was measured, within the range that was stated.
By their numbers in this assay, from the lowest: compounds 4, 3, 1 and 2 (each within the scatter of the next).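

In this assay, the step to 1-(2,3-dihydroxypropyl)-1H-1,2,3-triazol-4-yl in place of (piperidin-1-yl)methyl, on a saturated chain carbon bound to an aromatic nitrogen, is a 1.3-fold lower number from compound 3 to compound 4 (0.11 log units; within the scatter), so at this position the read-out stays within the scatter even when the piperidine ring is gone and a hydroxylated triazole stands in its place. The same holds for the longer amine chain, with 1-(2,3-dihydroxypropyl)-1H-1,2,3-triazol-4-yl in place of 3-(piperidin-1-yl)propyl giving a 1.4-fold lower number from compound 2 to compound 4 (0.13 log units; within the scatter), and for the two triazoles, where 1,2-dihydroxyethyl in place of 5-(hydroxymethyl)-2,2-dimethyl-1,3-dioxolan-4-yl gives a 1.4-fold lower number from compound 1 to compound 4 (0.13 log units; within the scatter). Nothing available accounts for how closely these values lie together.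

As far as these compounds go, it remains open whether a carboxylic acid, a morpholine ring or a plain alkyl chain at this position would produce a step beyond the scatter in this assay. The compounds shown also leave open how the opposite configuration of the 2,3-dihydroxypropyl group, or a triazole carrying a single hydroxyl group, would read.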